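From trifluoromethyl to fluoro in an antiproliferative series

The compounds below may be only part of what the source reports. "The series", "measured", "known", "first", "only" and "open" are said of these compounds alone.

Measured so far in a functional assay on MCF7 cells (Homo sapiens) for antiproliferative activity, read by MTT assay, with a stated time of 48 h (on this read-out higher numbers stand for weaker inhibition and lower numbers for stronger inhibition), for each compound:
Compound 1 (`Cc1ccc(-c2cc(NC(=O)/C=C/c3ccc(Cl)cc3)n[nH]2)cc1`): 1190 nM
Compound 2 (`Cc1ccc(-c2cc(NC(=O)/C=C/c3ccc(C(F)(F)F)cc3)n[nH]2)cc1`): 720 nM

Going by the values given here, only these two numbers exist so far, and a 1.7-fold lower number from compound 1 to compound 2 (0.22 log units; within the scatter) lies within the scatter, so compound 2 cannot be ranked apart from its sole measured neighbour. The next compound, compound 3 (`Cc1ccc(-c2cc(NC(=O)/C=C/c3ccc(F)cc3)n[nH]2)cc1`), carries fluoro in place of trifluoromethyl on an aromatic carbon, para to a large group (fluoro in place of trifluoromethyl on an aromatic carbon). Among the compounds with values here, one measured step bears on this change, because a 1.7-fold lower number from compound 1 to compound 2 (0.22 log units; within the scatter) also exchanges the group on that aromatic carbon, and it stayed within the scatter. Within the data shown here, no measured compound yet carries fluoro, so the data offer no direct guide to this group and no firm direction. In this assay no step beyond the scatter is therefore expected. The estimated step of a 1.4-fold higher number from compound 2 to compound 3 (0.14 log units; within the scatter) stays within that scatter. For compound 3 the estimated value is 1000 nM with an expected range of 480 nM to 2400 nM in this measurement.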

Compound 3, half-maximal inhibitory concentration: 950 nM
The estimate for compound 3 lay 1.1-fold (0.02 log units) above the measured number; the range from low to high includes it.
By their numbers in this assay, from the lowest: compounds 2, 3 and 1 (each within the scatter of the next).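

In this assay, fluoro now stands with chloro and trifluoromethyl on the aromatic carbon para to a large group, and the exchange of trifluoromethyl for fluoro gives a 1.3-fold higher number from compound 2 to compound 3 (0.12 log units; within the scatter) while the exchange of chloro for fluoro gives a 1.3-fold lower number from compound 1 to compound 3 (0.10 log units; within the scatter) on the same carbon. With the earlier step, all three pairs among these compounds now lie within the scatter, so a single exchange at this position has not yet separated any of them, even when 4 heavy atoms leave and 1 heavy atom enters. No independent measurement bears on why these numbers stay so close, so the result stands without an explanation.

What the compounds shown leave open is whether a group of another kind on this carbon, such as an amine, a carboxylic acid or a methoxy group, would produce a step beyond the scatter. Equally open, on these data alone, is whether exchanges elsewhere on the shared core, including at the amide hydrogen, would move the number further than these three groups have done.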